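Flipping One Stereocentre in a Serine Protease Inhibitor

The source may report more compounds than this note shows. Statements on the series, on what has been measured and on what is new or still open speak of the compounds shown alone.

Three measured compounds share one core and differ only in the amide at one end. Compound 1 `COc1cc(C(=O)N2C[C@@H](n3cc(C4CC4)nn3)C[C@H]2C(=O)N[C@H]2C[C@@H]2c2ccccc2)ccc1CN` gives 960 nM in an assay on isolated protein for inhibition of serine protease 1 (Homo sapiens), read by fluorescence; a higher number here means a weaker inhibitor, a lower number a stronger inhibitor. Compound 2 `CNC(=O)[C@@H]1C[C@H](n2cc(C3CC3)nn2)CN1C(=O)c1ccc(CN)c(OC)c1` gives 2100 nM in this assay, and compound 3 `COc1cc(C(=O)N2C[C@@H](n3cc(C4CC4)nn3)C[C@H]2C(=O)N2CC[C@@H](c3ccccc3)C2)ccc1CN` gives 330 nM. Exchanging the amide substituent moved the numbers only modestly: a 2.2-fold higher number from compound 1 to compound 2 (0.34 log units; beyond the scatter), a 2.9-fold lower number from compound 1 to compound 3 (0.46 log units; beyond the scatter) and a 6.4-fold lower number from compound 2 to compound 3 (0.80 log units; beyond the scatter). Compound 3 therefore stands lowest of the three and is the strongest inhibitor among them, with compound 1 nearest and compound 2 furthest.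

Compound 4 `COc1cc(C(=O)N2C[C@@H](n3cc(C4CC4)nn3)C[C@H]2C(=O)N2CC[C@H](c3ccccc3)C2)ccc1CN` keeps every atom and bond of compound 3 and changes only a spatial arrangement: the two compounds have the same atoms and bonds and differ only in configuration as drawn: 1 of 3 stereo elements differ; a stereocentre at a saturated ring carbon is drawn S in compound 3 and R in compound 4. Among the compounds with values here, no measured step bears on such a change; all three steps exchange one amide substituent for another, and each was modest in size. The effect of inverting a stereocentre is simply unknown from these data, so the expectation for compound 4 rests on compound 3 alone and must be drawn wide in both directions. Compound 4 is expected to give 800 nM in this assay, within a range of 200 nM to 3500 nM. The expected step is a 2.4-fold higher number from compound 3 to compound 4 (0.38 log units; beyond the scatter).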

Compound 4, half-maximal inhibitory concentration: 220 nM
For compound 4 the middle estimate is 3.6-fold (0.56 log units) above the measured one, and the stated range covers the measured number.
By their numbers in this assay, from the lowest: compounds 4 and 3 (each within the scatter of the next); then compound 1; then compound 2.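

In this assay, drawing the stereocentre at the saturated ring carbon as R rather than S gives a 1.5-fold lower number from compound 3 to compound 4 (0.18 log units; within the scatter), so at this position the two mirror-image arrangements of the phenyl-bearing carbon cannot be told apart by their numbers. Both arrangements also stand apart from the other amides, with a 4.4-fold lower number from compound 1 to compound 4 (0.64 log units; beyond the scatter) and a 9.5-fold lower number from compound 2 to compound 4 (0.98 log units; beyond the scatter), so in these compounds the advantage of the 3-phenylpyrrolidin-1-yl amide does not depend on which configuration this carbon has. The comparison isolates that one carbon, and the reason it can be read so directly is this: the fact that compounds 3 and 4 differ only in the configuration as drawn.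

The compounds shown leave open whether the phenyl group is needed at all, as a plain pyrrolidin-1-yl amide with no phenyl, or a piperidin-1-yl amide with a larger ring, could tell how much of this level depends on that group and on that ring. They also leave open what inverting either of the other two stereo elements would do, as these stay the same in compound 3 and compound 4.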